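The source may hold more compounds than are shown below. What is called first, only, known or untested is meant among the compounds shown, and "the series" means these compounds.

Compound 1, with the structure `Cc1cc(Cl)ccc1NC(=O)Nc1nc(Sc2c[nH]c3ccccc23)cc(N2CCN(Cc3ccccc3)CC2)n1`, is the starting point. In a functional assay on A549 cells (Homo sapiens) for inhibition, with a stated time of 72 h (a lower number here means a stronger inhibitor, a higher number a weaker inhibitor), compound 1 gives > 50000 nM, and this is a limit of the assay rather than a measured number. Compound 1 therefore stands only at the limit of > 50000 nM in this assay, at which 1 of the 3 values shown sits, with no value that could be compared directly with the others.

Two related compounds carry a pyrrolidine in place of the benzylpiperazine and were measured. Compound 2, `O=C(Nc1ccc(Cl)cc1)Nc1nc(Sc2c[nH]c3ccccc23)cc(N2CCCC2)n1`, gives 6410 nM in this assay. Compound 3, `O=C(Nc1ccccc1)Nc1nc(Sc2c[nH]c3ccccc23)cc(N2CCCC2)n1`, gives 21200 nM in this assay. Among the measured compounds shown here, the single measured step between them is a 3.3-fold higher number from compound 2 to compound 3 (0.52 log units; beyond the scatter).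

The unmeasured compound 4, `O=C(Nc1ccccc1)Nc1nc(Sc2c[nH]c3ccccc23)cc(N2CCN(Cc3ccccc3)CC2)n1`, differs from compound 1 by phenyl in place of 4-chloro-2-methylphenyl on an amide-type nitrogen. This change removes the chloro as well as the methyl, while the step from compound 2 to compound 3 shows what removing the chloro alone did on the pyrrolidine-bearing core.

For the measured compounds named here, since compound 1 already sits at the limit, and the one measured step of this kind made the number larger, compound 4 is expected to remain at or beyond the limit, with a step that the limit leaves unreadable from compound 1 to compound 4 expected. The estimated value for compound 4 is 120000 nM, with a likely range from 40000 nM to 400000 nM.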

Compound 4, half-maximal inhibitory concentration: > 50000 nM
Compound 4: only a limit was reported; the forecaster's own chance of this, stated with the estimate: 85%; the middle value is on the limit's open side.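

In this assay compound 4 gives > 50000 nM, which is a limit and not a number. Compound 1 also stands at a limit, so the step from compound 1 to compound 4 cannot be read: the limit of > 50000 nM in this assay, at which 2 of the 4 values shown sit.

The compounds shown leave open whether phenyl in place of 4-chloro-2-methylphenyl changes inhibition on this benzylpiperazine-bearing core.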